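Swapping a Benzyl Arm for a Pyridylmethyl Arm

The source may hold more compounds than are shown below. What is called first, only, known or untested is meant among the compounds shown, and "the series" means these compounds.

Compound 1 `c1cncc(CN(CCCCN(C[C@H]2Cc3ccccc3CN2)[C@H]2CCCc3cccnc32)Cc2cccnc2)c1` gives only a limit, > 30000 nM, in a functional assay on cells for agonist activity at C-X-C chemokine receptor type 4 (Homo sapiens), read by fluorescence and calcium flux, with a stated time of 90 s; a higher number here means that more compound is needed for the effect, a lower number that less compound is needed.
Compound 2 `c1ccc(CNCCCCN(C[C@H]2Cc3ccccc3CN2)[C@H]2CCCc3cccnc32)cc1` likewise gives only a limit, > 30000 nM, in this assay.
Compound 3 `c1ccc2c(c1)CN[C@@H](CN(Cc1ccc(CNCc3ccncc3)cc1)[C@H]1CCCc3cccnc31)C2` also gives only a limit, > 30000 nM, in this assay.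

Compound 2 therefore stands where every measured compound stands: at the limit of > 30000 nM in this assay, at which 3 of the 3 values shown sit. Going by the values given here, no number sits below that limit, so no step between measured compounds can be sized.

Compound 4 `C(=C/CN(C[C@H]1Cc2ccccc2CN1)[C@H]1CCCc2cccnc21)\CNCc1ccccn1` differs from compound 2 by a group of 11 heavy atoms (9 carbon, 2 nitrogen; one six-membered aromatic ring with 1 hetero atom) in place of a group of 11 heavy atoms (10 carbon, 1 nitrogen; one six-membered aromatic ring of carbon only), on a saturated chain carbon bound to an amine nitrogen. Among the compounds with values here, nothing among the measured compounds shows that such a change moves the read-out, so the step from compound 2 to compound 4 is expected to be no larger than the usual scatter, and most likely to end again at the limit.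

The expected value for compound 4 in this assay is 30000 nM, with a range from 10000 nM to 100000 nM. This means the expected step is a number no higher from compound 2 to compound 4 (the limit leaves the size open).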

Compound 4, half-maximal effective concentration: > 30000 nM
Compound 4 was reported as a limit; the forecaster's own chance of this, stated with the estimate: 85%; the middle value lies on the limit itself.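

Going by these compounds alone, compound 2 and compound 4 both end at a limit, so no step between them can be read in this assay. Whether this change of group moves the read-out at all stays open, with no actual number among the four compounds shown.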